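Removing the fluoro from compound 1 in the reporter assay

The source may hold more compounds than are shown below. What is called first, only, known or untested is meant among the compounds shown, and "the series" means these compounds.

Among the compounds with values here, compound 1 `CC(C)OC(=O)N1CCC(Oc2ncnc3c2CCN3c2ccc(S(C)(=O)=O)cc2F)CC1` is one of three compounds measured in a functional assay on CHO-K1 cells with Glucose-dependent insulinotropic receptor (Homo sapiens) as the target, read by a luciferase reporter, with a stated time of 5 h; on this read-out higher numbers stand for larger maximal responses and lower numbers for smaller maximal responses. In this assay compound 1 gives 91%, the second highest of the three numbers. Compound 2 `CC(C)(C)OC(=O)N1CCC(Oc2cccc3c2CCN3c2ccc(S(C)(=O)=O)cc2)CC1`, which carries a tert-butyl carbamate and no fluoro, gives 92% in this assay, a number within the scatter of compound 1. Compound 3 `CC(C)OC(=O)N1CCC(Oc2cccc3c2CCN3c2ccc(S(C)(=O)=O)cc2F)CC1` gives 62% in this assay, a number beyond the scatter below compound 1. Within the data shown here, compound 2 and compound 3 each differ from compound 1 in more than one place, so no single step between measured compounds is available.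

Compound 4 `CC(C)OC(=O)N1CCC(Oc2ncnc3c2CCN3c2ccc(S(C)(=O)=O)cc2)CC1` has not yet been measured. It differs from compound 1 in one place: hydrogen in place of fluoro on an aromatic carbon. Cut one bond further out, the change reads 2-fluoro-4-(methylsulfonyl)phenyl to 4-(methylsulfonyl)phenyl. Among the measured compounds, compound 2 lacks this fluoro and gives 92%, while compound 3 keeps it and gives 62%; these two also differ in the carbamate, so the pair does not isolate the change. The step from compound 1 to compound 4 is expected to be a number 1 percentage points lower from compound 1 to compound 4 (within the scatter), within the scatter in either direction. Compound 4 is estimated at 90%, with a range from 72% to 104%.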

Compound 4, largest response reached (reported as percent of maximum), in percent of the reference or control that the assay uses: 154%
For compound 4 the middle estimate is 64 percentage points below the measured one, outside the stated range (above it).
By their numbers in this assay, from the lowest: compound 3; then compounds 1 and 2 (each within the scatter of the next); then compound 4.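

In this assay, within the data shown here, replacing the fluoro with hydrogen on the six-membered aromatic ring of carbon gives a number 63 percentage points higher from compound 1 to compound 4 (beyond the scatter), so this position, which the earlier compounds left undecided, has a large influence on the read-out. Compound 2 and compound 3 differ from compound 1 in more than one place and could not assign any difference to this atom, whereas compound 1 and compound 4 share everything except the change from 2-fluoro-4-(methylsulfonyl)phenyl to 4-(methylsulfonyl)phenyl, so the whole step belongs to that one substitution. Nothing available here accounts for why so small a change moves the maximal response this far.

The compounds shown leave open whether the same change would produce a step of this size on the core of compound 3 or alongside a tert-butyl carbamate, as only one matched pair speaks to it. They also leave open how other groups at this place, such as chloro, methyl or methoxy, would read in this assay, and so whether hydrogen is unusual here or fluoro is.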